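Shortening the linker on the sulfonamide nitrogen

This account rests on a few compounds, and the source may have more. Where it says the series, first, only, none or still open, it means among the compounds named here.

Compound 3 `CN(C)S(=O)(=O)c1ccccc1Nc1cc(-c2ccc3ccn(C)c3c2)c2nccnc2c1` sits second highest of the three numbers in an assay on lysate for inhibition of 6-phosphofructo-2-kinase/fructose-2,6-bisphosphatase 3 (Homo sapiens), with stated times of 0.5 min and 45 min (a higher number here means a weaker inhibitor, a lower number a stronger inhibitor), where compound 3 gives 7670 nM; its nearest neighbour is compound 1 `CN1CCC(CNS(=O)(=O)c2ccccc2Nc2cc(-c3ccc4ccn(C)c4c3)c3nccnc3c2)C1`, which in this assay gives 4640 nM, and its furthest is compound 2 `Cn1ccc2ccc(-c3cc(Nc4ccccc4S(N)(=O)=O)cc4nccnc34)cc21`, which gives 37600 nM. Compound 4 `CN1CCC(NS(=O)(=O)c2ccccc2Nc2cc(-c3ccc4ccn(C)c4c3)c3nccnc3c2)C1` differs from compound 3 in one place: (1-methylpyrrolidin-3-yl)amino in place of dimethylamino on a sulfonyl sulfur. For the measured compounds named here, two measured steps bear on this. The step of a 1.7-fold higher number from compound 1 to compound 3 (0.22 log units; within the scatter) shows that swapping a substituted amino group for dimethylamino on the sulfonyl sulfur hardly moved the number, while the step of a 4.9-fold lower number from compound 2 to compound 3 (0.69 log units; beyond the scatter) shows that the bare amino group gave a weaker inhibitor than dimethylamino. Compound 4 carries a substituted, not a bare, amino group, and its ring is held one bond closer than in compound 1, so the expectation is a step of a 1.4-fold lower number from compound 3 to compound 4 (0.14 log units; within the scatter) from compound 3 to compound 4, within the scatter. Compound 4 is therefore estimated at 5500 nM, with a range from 2200 nM to 14000 nM.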

Compound 4, half-maximal inhibitory concentration: 3160 nM
For compound 4 the middle estimate is 1.7-fold (0.24 log units) above the measured one; measured number inside the range.
By their numbers in this assay, from the lowest: compounds 4, 1 and 3 (each within the scatter of the next, the first and the last beyond it); then compound 2.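

On the sulfonyl sulfur, the (1-methylpyrrolidin-3-yl)amino group separates from dimethylamino in this assay with a 2.4-fold lower number from compound 3 to compound 4 (0.39 log units; beyond the scatter) and so gives a difference beyond the scatter, which the (1-methylpyrrolidin-3-yl)methyl amino group of compound 1 did not give. Set against the bare sulfonamide, the 1-methylpyrrolidin-3-yl group gives a 12-fold lower number from compound 2 to compound 4 (1.08 log units; beyond the scatter) and this is the only step of large size among these compounds. Shortening the link to the ring gives a 1.5-fold lower number from compound 1 to compound 4 (0.17 log units; within the scatter) and that stays within the scatter, so the two attachments cannot be told apart here.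

On these data alone, it remains open whether a cyclopentyl or a piperidin-4-yl group in the same place would hold the number, and so whether the ring nitrogen matters at all. No measurement at hand accounts for these differences.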